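Series notes: loss of the benzoyl ester in compound 4

This account rests on a few compounds, and the source may have more. Where it says the series, first, only, none or still open, it means among the compounds named here.

The shared core carries an ester on the ring-bound oxygen. Compound 1 `O=C(OC1(C(=O)Nc2ccc([N+](=O)[O-])cc2)CCCCC1)c1ccc(C(F)(F)F)cc1` in a functional assay on NFS-60 cells (Mus musculus) for inhibition, read by MTT assay, with a stated time of 72 h (a lower number here means a stronger inhibitor, a higher number a weaker inhibitor), gives 26 nM; compound 2 `Cc1ccc(C(=O)OC2(C(=O)Nc3ccc([N+](=O)[O-])cc3)CCCCC2)cc1` gives 45.4 nM, and the two stand within the scatter of each other, as a 1.7-fold higher number from compound 1 to compound 2 (0.24 log units; within the scatter) shows. Compound 3 `O=C(OC1(C(=O)Nc2ccc([N+](=O)[O-])cc2)CCCCC1)c1ccccc1` gives 766 nM, the highest number of the three: a 29-fold higher number from compound 1 to compound 3 (1.47 log units; beyond the scatter) and a 17-fold higher number from compound 2 to compound 3 (1.23 log units; beyond the scatter) are both large steps.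

Compound 4 `O=C(Nc1ccc([N+](=O)[O-])cc1)C1(O)CCCCC1` takes the next step, (hydrogen in place of benzoyl on an oxygen on a saturated carbon). Among the compounds with values here, no measured step removes the ester itself; the three measured steps only change a group on the aromatic carbon of that benzoyl, and each removal there cost potency. Compound 4 removes the whole benzoyl, including the aromatic ring on which those groups sat, so a further weakening, from compound 3, is expected, and its size is uncertain: the step of a 7.8-fold higher number from compound 3 to compound 4 (0.89 log units; beyond the scatter) is an estimate only. For compound 4 the expected value is 6000 nM, with a range from 1200 nM to 40000 nM.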

Compound 4, half-maximal inhibitory concentration: 716 nM
Compound 4: the middle estimate sits 8.4-fold (0.92 log units) above what was measured; measured number outside the range, below it.
By their numbers in this assay, from the lowest: compounds 1 and 2 (each within the scatter of the next); then compounds 4 and 3 (each within the scatter of the next).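

In this assay, the benzoyl ester and the free hydroxy on this oxygen stand within the scatter of each other (a 1.1-fold lower number from compound 3 to compound 4 (0.03 log units; within the scatter)), so the unsubstituted benzoyl shows no measurable contribution of its own. Among these compounds, the ester matters only when its aromatic carbon carries a further group: the (4-methylphenyl)carbonyl compound stands a large step from the hydroxy (a 16-fold higher number from compound 2 to compound 4 (1.20 log units; beyond the scatter)), which places the earlier methyl and trifluoromethyl effects on those groups within the benzoyl, not on the ester as such. Nothing at hand accounts for this pattern.

On these data alone, whether an amine in place of the ester oxygen would keep the potency of compound 1 remains open. Also open, as far as these compounds go, is whether a carboxylic acid or a longer chain on the aromatic carbon of the benzoyl would behave like methyl or like hydrogen.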